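A few compounds are considered here, and "the series" means these few. Any claim that something is new, unique, unknown or untested is made for them only; others in the source may bear on it.

Compound 1 `CCN(CC)c1ccc(/C=N/NC(=O)CNC(=O)c2ccc(F)cc2)c(OCc2ccccc2Cl)c1` gives > 50000 nM in a functional assay on HepG2 cells (Homo sapiens) for inhibition, read by MTT assay, with a stated time of 24 h (a lower number here means a stronger inhibitor, a higher number a weaker inhibitor), which is a limit and not a number. Compound 2 `CCN(CC)c1ccc(/C=N/NC(=O)CNC(=O)c2ccc(C#N)cc2)c(OCc2ccccc2Cl)c1` gives > 50000 nM in this assay, which is also a limit. Together they stand at the limit of > 50000 nM in this assay, at which 2 of the 2 values shown sit. Compound 3 `CCN(CC)c1ccc(/C=N/NC(=O)CNC(=O)c2ccc(C)cc2)c(OCc2ccccc2Cl)c1` carries methyl in place of cyano on an aromatic carbon, para to a large group (methyl in place of cyano on an aromatic carbon). Among the compounds with values here, the only measured guide is a step that the two limits leave unreadable from compound 1 to compound 2, which offers no size, so no change beyond the scatter is expected in this assay, in either direction. The estimated size is a step that the limit leaves unreadable from compound 2 to compound 3. For compound 3 the expected value is 60000 nM, with an estimated range from 25000 nM to 150000 nM.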

Compound 3, half-maximal inhibitory concentration: > 50000 nM
Compound 3: a limit, no number; the forecaster's own chance of this, stated with the estimate: 80%; the middle value does not contradict the limit.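

Within the data shown here, no step among compound 1, compound 2 and compound 3 can be read, since each result is a limit and not a number: the limit of > 50000 nM in this assay, at which 3 of the 3 values shown sit. The compounds shown leave open whether swapping fluoro, cyano and methyl makes any difference in this assay.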